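Dropping the hydroxy from compound 3's side chain

A few compounds are considered here, and "the series" means these few. Any claim that something is new, unique, unknown or untested is made for them only; others in the source may bear on it.

Compound 3 `O=C(CN(c1nc(Cl)nc2[nH]cnc12)C1CC1)N[C@@H](CO)C(=O)O` gives 39.8% in a functional assay on the whole organism (Tail, strain ICR) with Mus musculus as the target, in the tail flick test, with a stated time of 60 min, at a dose of 25 umol/kg by the oral route (on this read-out higher numbers stand for a stronger effect at the one dose given and lower numbers for a weaker effect), the second highest of three numbers. Compound 1 `O=C(CN(c1nc(Cl)nc2[nH]cnc12)C1CC1)N[C@@H](CO)C(=O)OCc1ccccc1` gives 34.2% in this assay, and compound 2 `CC(C)[C@H](NC(=O)CN(c1nc(Cl)nc2[nH]cnc12)C1CC1)C(=O)OCc1ccccc1` gives 55.5% in this assay. Compound 4 `C[C@H](NC(=O)CN(c1nc(Cl)nc2[nH]cnc12)C1CC1)C(=O)O` is not yet measured; it differs from compound 3 by hydrogen in place of hydroxy on a saturated chain carbon, two bonds along the chain from an amide-type nitrogen and a carbonyl carbon. For the measured compounds named here, two measured steps bear on this. The change a number 5.6 percentage points higher from compound 1 to compound 3 (within the scatter) touched a different part of the molecule. The change a number 21.3 percentage points higher from compound 1 to compound 2 (beyond the scatter) also replaced the hydroxymethyl group, and that is the closer precedent. Because that step a number 21.3 percentage points higher from compound 1 to compound 2 (beyond the scatter) was modest, a smaller rise is expected here, a number 8.2 percentage points higher from compound 3 to compound 4 (within the scatter). Compound 4 is therefore estimated at 48%, ranging from 32% to 64%.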

Compound 4, a percentage reported as activity, at one dose (the size of the read-out at that dose, not a potency): 44.6%
The estimate for compound 4 lay 3.4 percentage points above the measured number; the range from low to high includes it.
By their numbers in this assay, from the lowest: compounds 1, 3 and 4 (each within the scatter of the next, the first and the last beyond it); then compound 2.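

In this assay, hydrogen in place of hydroxy on this saturated chain carbon gives a number 4.8 percentage points higher from compound 3 to compound 4 (within the scatter). On the free acid, then, hydroxymethyl and methyl cannot be told apart at this position, and compound 4 keeps a clear effect without the hydroxy. Nothing available here explains this result.

The compounds shown leave open how a group carrying an amine, such as aminomethyl, or a longer chain, such as 2-hydroxyethyl, would read at this position. As far as these compounds go, whether losing the hydroxy would read the same with the benzyl ester in place also stays open.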